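Cytotoxicity notes on a thymidine urea and thiourea series

The source may hold more compounds than are shown below. What is called first, only, known or untested is meant among the compounds shown, and "the series" means these compounds.

Compound 1 `COc1ccc(NC(=O)NC[C@H]2O[C@H](n3cc(C)c(=O)[nH]c3=O)C[C@@H]2O)cc1` is the reference point. In an ADME assay on MRC5 cells (Homo sapiens) for cytotoxicity (a lower number here means that less compound is tolerated, a higher number that more compound is tolerated), compound 1 gives > 50000 nM, which is a limit of the assay and not a number. Compound 2 `Cc1cn([C@@H]2C[C@H](O)[C@@H](CNC(=S)Nc3ccc(Cl)c(C(F)(F)F)c3)O2)c(=O)[nH]c1=O` gives > 50000 nM in this assay, again a limit. Compound 3 `Cc1cn([C@@H]2C[C@H](O)[C@@H](CNC(=S)Nc3ccc(OCc4ccccc4)cc3)O2)c(=O)[nH]c1=O` gives > 50000 nM in this assay, also a limit. Among the measured compounds shown here, compound 1 therefore stands at the limit of > 50000 nM in this assay, at which 3 of the 3 values shown sit, together with every other value in the set, so no step between measured compounds can be sized. Compound 4 `Cc1cn([C@@H]2C[C@H](O)[C@@H](CNC(=O)Nc3ccc(-c4ccc(C(F)(F)F)nc4)cc3)O2)c(=O)[nH]c1=O` differs from compound 1 by 6-(trifluoromethyl)pyridin-3-yl in place of methoxy on an aromatic carbon. For the measured compounds named here, with three limits and no measured step, no direction can be read from the data. Compound 4 is expected to give 50000 nM in this assay, with a range from 20000 nM to 100000 nM. The step of a number no higher from compound 1 to compound 4 (the limit leaves the size open) is expected to stay within the scatter.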

Compound 4, half-maximal cytotoxic concentration: > 50000 nM
Compound 4: a limit, no number; the forecaster's own chance of this, stated with the estimate: 65%; the middle value sits exactly at the limit.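

Among the compounds shown here, compound 4 gives > 50000 nM, again a limit and not a number, so no step from compound 1 to compound 4 can be read. The compounds shown leave open whether anything separates them in this assay: the limit of > 50000 nM in this assay, at which 4 of the 4 values shown sit.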